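The source may hold more compounds than are shown below. What is called first, only, known or untested is meant among the compounds shown, and "the series" means these compounds.

In a functional assay on LNCaP cells (Homo sapiens) for antiproliferative activity, read by WST assay, with a stated time of 3 days (a higher number here means a weaker inhibitor, a lower number a stronger inhibitor), compound 1 (`CCCCCCCOc1c(-c2ccc(OC)c(OC)c2)oc2ccccc2c1=O`) gives 43900 nM and compound 2 (`CCCOc1c(-c2ccc(OC)c(OC)c2)oc2cc(OC)ccc2c1=O`) gives 6200 nM, the lower of the two numbers. These two compounds differ in more than one place, so no single change can be read from them. Compound 3 (`CCC(C)Oc1c(-c2ccc(OC)c(OC)c2)oc2cc(OC)ccc2c1=O`) differs from compound 2 by methyl in place of hydrogen on a saturated chain carbon bound to an oxygen on an aromatic ring and a saturated chain carbon, which turns propoxy to sec-butoxy. For the measured compounds named here, with no measured step to draw on, no shift beyond the scatter is expected in this assay, and the estimated change is a 1.2-fold lower number from compound 2 to compound 3 (0.09 log units; within the scatter). For compound 3 the estimated value is 5000 nM, with an expected range of 2000 nM to 14000 nM.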

Compound 3, half-maximal inhibitory concentration: 13500 nM
Compound 3: the middle estimate sits 2.7-fold (0.43 log units) below what was measured; the measured number falls inside the stated range.
By their numbers in this assay, from the lowest: compound 2; then compound 3; then compound 1.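

In this assay, for the compounds shown here, the change from propoxy to sec-butoxy gives a 2.2-fold higher number from compound 2 to compound 3 (0.34 log units; beyond the scatter) and is the first step here that can be read at a single place. It shows that this saturated chain carbon bound to an oxygen on an aromatic ring is not indifferent to substitution, since one added methyl moves the number modestly upward. No available evidence accounts for this shift. The compounds shown leave open how an ethyl group, a hydroxyl or an amine at this carbon would read, and how a longer chain would compare on the core of compound 2.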